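The source may hold more compounds than are shown below. What is called first, only, known or untested is meant among the compounds shown, and "the series" means these compounds.

Measured so far:
compound 1 `Nc1n[nH]c2cc(-c3ccc(=O)n(Cc4ccccc4F)c3)ccc12` gives < 10 mL.min-1.g-1 (a limit, not a number)
compound 2 `O=c1ccc(-c2ccc3cn[nH]c3c2)cn1Cc1cccc(Cl)c1` gives 52 mL.min-1.g-1

Both readings come from an ADME assay on microsomes (Mus musculus) for metabolic stability, read by LC-MS, using NADPH, with a stated time of 1 h, tested at 1 uM (a higher number here means faster removal of the compound, a lower number slower removal), and no others are at hand. Among the measured compounds shown here, compound 2 at 52 mL.min-1.g-1 holds the only true number here. Compound 3 `O=c1ccc(-c2ccc3cn[nH]c3c2)cn1Cc1ccccc1F` differs from compound 2 in one place (2-fluorophenyl in place of 3-chlorophenyl on a saturated chain carbon bound to an aromatic nitrogen): 2-fluorophenyl in place of 3-chlorophenyl on a saturated chain carbon bound to an aromatic nitrogen. For the measured compounds named here, no measured step shows this change on its own. Compound 1 carries the same 2-fluorobenzyl group on a different core and reads < 10 mL.min-1.g-1 as a limit and not a number, which gives only a weak hint. A modest fall is therefore expected (a 2.1-fold lower number from compound 2 to compound 3 (0.32 log units; beyond the scatter)) and no more. For compound 3 the expected value is 25 mL.min-1.g-1 with an estimated range from 11 mL.min-1.g-1 to 55 mL.min-1.g-1 for most repeat measurements.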

Compound 3, intrinsic clearance in microsomes: 246 mL.min-1.g-1
For compound 3 the middle estimate is 9.8-fold (0.99 log units) below the measured one, and the stated range ends below it.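

In this assay, 2-fluorophenyl in place of 3-chlorophenyl gives a 4.7-fold higher number from compound 2 to compound 3 (0.67 log units; beyond the scatter), so the number moves with the group carried at this place on the shared core. The 2-fluorobenzyl group does not bring a low number by itself: with this group held constant, hydrogen in place of amino on an aromatic carbon gives an at least 24-fold higher number from compound 1 to compound 3 (1.39 log units; beyond the scatter). The reading of compound 1 is a limit and not a number, so this step has no fixed upper size: the limit of < 10 mL.min-1.g-1 in this assay, at which 1 of the 3 values shown sits.

The compounds shown do not tell whether the amino group would have the same effect alongside 3-chlorobenzyl. They also do not separate the change of halogen from the change of its place on the ring, and a plain benzyl or a methoxybenzyl group would give further points of comparison.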